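The compounds below may be only part of what the source reports. "The series", "measured", "known", "first", "only" and "open" are said of these compounds alone.

Measured compounds:
- compound 1 `O=C(O)c1ccccc1-c1ccc(CCc2ncc(CC3CCC3)[nH]2)cc1`, 7.1 nM
- compound 2 `O=C(O)c1ccccc1-c1ccc(CCc2ncc(CC3CCCC3)[nH]2)cc1`, 7.9 nM
- compound 3 `O=C(O)c1ccccc1-c1ccc(CCc2ncc(-c3ccccc3)[nH]2)cc1`, 872 nM

All three were tested in an in vitro functional assay on cells for agonist activity at Bombesin receptor subtype-3 (Mus musculus), read by luminescence and calcium flux; a lower number here means that less compound is needed, a higher number that more compound is needed for the effect. Compound 1 gives the lowest number of the three, 7.1 nM; its nearest neighbour is compound 2 with 7.9 nM, and the step of a 1.1-fold higher number from compound 1 to compound 2 (0.05 log units; within the scatter) is within the usual scatter. Compound 3, which carries a phenyl on the aromatic carbon, stands far off: the step of a 120-fold higher number from compound 1 to compound 3 (2.09 log units; beyond the scatter) is large, as is a 110-fold higher number from compound 2 to compound 3 (2.04 log units; beyond the scatter).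

Compound 4 `CC(C)(C)CCc1cnc(CCc2ccc(-c3ccccc3C(=O)O)cc2)[nH]1` has not yet been measured. It differs from compound 1 in one place, (neopentyl in place of cyclobutyl on a saturated chain carbon bound to an aromatic carbon). The step that bears on it most directly is a 1.1-fold higher number from compound 1 to compound 2 (0.05 log units; within the scatter), which shows that enlarging a saturated group at this position by one carbon changed little. The only large movement, a 120-fold higher number from compound 1 to compound 3 (2.09 log units; beyond the scatter), came with an aromatic group, which compound 4 does not carry. A saturated, branched group of a similar size is therefore expected to leave this assay close to where compound 1 stands, with a step of a 1.4-fold higher number from compound 1 to compound 4 (0.15 log units; within the scatter) that is expected to stay within the scatter. The estimate for compound 4 is 10 nM, with a range from 4 nM to 30 nM.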

Compound 4, half-maximal effective concentration: 6.2 nM
Compound 4: the middle estimate sits 1.6-fold (0.21 log units) above what was measured, within the range that was stated.
By their numbers in this assay, from the lowest: compounds 4, 1 and 2 (each within the scatter of the next); then compound 3.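

In this assay, a saturated ring turns out not to be needed at this place: neopentyl in place of cyclobutyl gives a step within the scatter (a 1.1-fold lower number from compound 1 to compound 4 (0.06 log units; within the scatter)), and neopentyl in place of cyclopentyl does the same (a 1.3-fold lower number from compound 2 to compound 4 (0.11 log units; within the scatter)). Until now, every compound with a low number carried a saturated ring in this group, so the ring and the low number could not be told apart, whereas compound 4 has a low number with an open, branched chain. The large gap from the phenyl compound also holds for this ringless group (a 140-fold lower number from compound 3 to compound 4 (2.15 log units; beyond the scatter)), so among the compounds shown, phenyl stands apart from all three saturated groups, whether or not they carry a ring.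

The compounds shown leave open whether that gap follows the aromatic ring itself or the loss of the saturated chain carbon, a question that a benzyl or cyclohexyl group on the same aromatic carbon would address, and whether a longer chain or a chain carrying an amine or hydroxyl group would stay close to compound 4. No measurement at hand gives a reason for any of these numbers.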